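Notes on a ring exchange at the amide-type nitrogen

The compounds below may be only part of what the source reports. "The series", "measured", "known", "first", "only" and "open" are said of these compounds alone.

Measured so far:
compound 1 `Cc1nc(N)sc1CCCN/C(N)=N/C(=O)N[C@H](C)c1ccccc1`: 17.8 nM
compound 2 `Cc1nc(N)sc1CCCN/C(N)=N/C(=O)NC(c1ccccc1)C(C)C`: 35.5 nM

Both numbers come from an assay on membranes from Sf9 cells for displacement of a labelled ligand from histamine H2 receptor (Homo sapiens), read by scintillation counting, with a stated time of 60 min; a lower number here means a stronger inhibitor, a higher number a weaker inhibitor. Compound 1 has the lower of the two numbers, but compound 2 sits within the scatter of it, so no order between them can be drawn. Compound 3 `Cc1nc(N)sc1CCCN/C(N)=N/C(=O)NC(C)c1ccco1` is not yet measured. It differs from compound 1 by 1-(furan-2-yl)ethyl in place of 1-phenylethyl on an amide-type nitrogen. Going by the values given here, no measured pair in the set shows a change of this kind, so nothing beyond the scatter is expected in this assay, in either direction. Compound 3 is expected to give about 25 nM, within 8 nM to 80 nM. The estimated step is a 1.4-fold higher number from compound 1 to compound 3 (0.15 log units; within the scatter).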

Compound 3, inhibition constant: 31.6 nM
Compound 3: the middle estimate sits 1.3-fold (0.10 log units) below what was measured; low and high end bracket the measured number.
By their numbers in this assay, from the lowest: compounds 1, 3 and 2 (each within the scatter of the next).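

In this assay, 1-(furan-2-yl)ethyl in place of 1-phenylethyl on the amide-type nitrogen gives a 1.8-fold higher number from compound 1 to compound 3 (0.25 log units; within the scatter) and so stays within the scatter. At this position, the five-membered aromatic ring with its oxygen can therefore stand in for the six-membered carbon ring without a readable loss. No available data bear on a reason for this result.

Open, as far as these compounds go, is whether a thiophene or cyclohexyl ring behaves the same way here. Also open, from the compounds shown here alone, is what the defined stereocentre of 1-phenylethyl contributes, since 1-(furan-2-yl)ethyl carries none.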